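Compound 1 gives up its 4-ethylpiperazin-1-yl group

The source may hold more compounds than are shown below. What is called first, only, known or untested is meant among the compounds shown, and "the series" means these compounds.

In a functional assay on HCT-116 cells (Homo sapiens) for inhibition, read by CCK-8 assay, with a stated time of 48 h (a higher number here means a weaker inhibitor, a lower number a stronger inhibitor), compound 1 `CCN1CCN(C(=S)SCC(=O)N(Cc2ccc(OC)cc2)c2cc(OC)c(OC)c(OC)c2)CC1` gives 7700 nM. Compound 3 `COc1ccc(CN(C(=O)CSC(=S)N2CCN(Cc3ccc(C(C)(C)C)cc3)CC2)c2cc(OC)c(OC)c(OC)c2)cc1` gives 6890 nM, level with it, and compound 2 `COc1ccc(CN(C(=O)CSC(=S)N2CCN(C(=O)OC(C)(C)C)CC2)c2cc(OC)c(OC)c(OC)c2)cc1` gives 620 nM. Compound 1 therefore stands at the upper end of the three numbers, together with compound 3.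

Compound 4 `COc1ccc(CN(C(=O)CSC(=S)N2CCc3cc(Br)ccc32)c2cc(OC)c(OC)c(OC)c2)cc1` has not yet been measured. It carries 5-bromo-2,3-dihydro-1H-indol-1-yl in place of 4-ethylpiperazin-1-yl on a thiocarbonyl carbon. The measured steps bear on this change only indirectly, as each alters the group on an amine nitrogen in a ring and leaves that ring in place. Tert-butoxycarbonyl in place of ethyl gives a 12-fold lower number from compound 1 to compound 2 (1.09 log units; beyond the scatter), a large step. 4-(tert-butyl)benzyl in place of tert-butoxycarbonyl gives an 11-fold higher number from compound 2 to compound 3 (1.05 log units; beyond the scatter), also large. Compound 3 nevertheless ends level with the starting point, at a 1.1-fold lower number from compound 1 to compound 3 (0.05 log units; within the scatter), within the scatter.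

So this end of the molecule can move the number greatly or not at all, and no measured compound carries the entering group. With compound 2 showing how low the number can go at 620 nM, a moderate move toward a lower number is expected in this assay. For compound 4 the expected step is a 4.3-fold lower number from compound 1 to compound 4 (0.63 log units; beyond the scatter). For compound 4 the estimated value is 1800 nM, within an expected range from 400 nM to 7500 nM.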

Compound 4, half-maximal inhibitory concentration: 8060 nM
Estimate against measurement, compound 4: 4.5-fold (0.65 log units) below; measured number above the stated range.
By their numbers in this assay, from the lowest: compound 2; then compounds 3, 1 and 4 (each within the scatter of the next).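

In this assay, replacing 4-ethylpiperazin-1-yl on the thiocarbonyl carbon with 5-bromo-2,3-dihydro-1H-indol-1-yl gives a 1.0-fold higher number from compound 1 to compound 4 (0.02 log units; within the scatter). The earlier steps shown here only changed the group on a ring nitrogen, whereas this one replaces the whole ring with a group holding a five-membered non-aromatic ring, a six-membered aromatic ring of carbon only and a bromine, and the number does not move. Compound 1, compound 3 and compound 4 now lie within the scatter of their neighbours in the ranking, so among the four compounds only compound 2, at 620 nM, gives a clearly different number. No other measurement is available to account for this result.

The compounds shown leave open whether the plain 2,3-dihydro-1H-indol-1-yl group, without its bromine, or a chlorine in the bromine's stead, would read the same in this assay. They also leave open whether the number of compound 2 depends on the piperazine ring, which a piperidine carrying tert-butoxycarbonyl would test, or on the carbamate itself, which a methyl carbamate or a simple acetyl amide on the same ring would test.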